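The source may report more compounds than this note shows. Statements on the series, on what has been measured and on what is new or still open speak of the compounds shown alone.

Working notes on the series, all read in a functional assay on P388D1 cells (Homo sapiens) for antiproliferative activity, read by sulforhodamine B assay, with a stated time of 48 h; a lower number here means a stronger inhibitor, a higher number a weaker inhibitor. Compound 1 (`Cc1cccc(NS(=O)(=O)c2ccc(N3CCNC3=O)cc2)c1`) gives 250 nM, compound 2 (`CCc1cccc(NS(=O)(=O)c2ccc(N3CCNC3=O)cc2)c1`) gives 250 nM, and compound 3 (`O=C1NCCN1c1ccc(S(=O)(=O)Nc2cccc(Br)c2)cc1`) gives 90 nM. Compound 3 holds the lowest of these three numbers, and the other two lie the same distance from it.

The next compound is compound 4 (`Cc1cc(C)cc(NS(=O)(=O)c2ccc(N3CCNC3=O)cc2)c1`), with 3,5-dimethylphenyl in place of 3-bromophenyl on a sulfonamide nitrogen.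

For the measured compounds named here, three measured steps bear on this change. Bromo in place of methyl gave a 2.8-fold lower number from compound 1 to compound 3 (0.44 log units; beyond the scatter), and bromo in place of ethyl gave a 2.8-fold lower number from compound 2 to compound 3 (0.44 log units; beyond the scatter). Both are modest. Methyl in place of hydrogen on the saturated chain gave no change at the digits printed from compound 1 to compound 2 (within the scatter). The present change runs opposite to the two bromo steps, so a modest move to a higher number is expected. Going by the values given here, no measured compound carries 3,5-dimethylphenyl, so the range is kept wide.

The expected step is a 2.6-fold higher number from compound 3 to compound 4 (0.41 log units; beyond the scatter). The estimate for compound 4 is 230 nM, with an expected range of 100 nM to 500 nM.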

Compound 4, half-maximal inhibitory concentration: 210 nM
Beside the measured number, compound 4's estimate is 1.1-fold (0.04 log units) above it; measured number inside the range.
By their numbers in this assay, from the lowest: compound 3; then compounds 4, 1 and 2 (each within the scatter of the next).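

In this assay, methyl in place of hydrogen on an aromatic carbon gives a 1.2-fold lower number from compound 1 to compound 4 (0.08 log units; within the scatter) and 3,5-dimethylphenyl in place of 3-ethylphenyl gives a 1.2-fold lower number from compound 2 to compound 4 (0.08 log units; within the scatter) so neither a second methyl nor the swap from the ethyl compound separates these compounds. The step of a 2.3-fold higher number from compound 3 to compound 4 (0.37 log units; beyond the scatter) shows that 3,5-dimethylphenyl on the sulfonamide nitrogen does not match 3-bromophenyl, leaving compound 3 alone among the four, with compounds 1, 2 and 4 together. No measurement at hand accounts for this gap.

From the compounds shown here alone, it remains open whether 3,5-dibromophenyl would give a lower number than compound 3. Going by these compounds, the effect of chloro, methoxy or an amine on the aromatic ring also remains open.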